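Tert-butyl for thiophen-2-yl on the shared core

This account rests on a few compounds, and the source may have more. Where it says the series, first, only, none or still open, it means among the compounds named here.

Of the compounds shown here, three on the shared core have been measured in an assay on isolated protein for inhibition of serine/threonine-protein kinase Chk2 (Homo sapiens), read by mobility shift assay, tested at 30 uM; on this read-out lower numbers stand for less inhibition and higher numbers for more inhibition at the one concentration tested (going by the name of the read-out). Compound 1 `Cc1cc2[nH]nc(N)c2c(=O)[nH]1` carries a methyl on an aromatic carbon and in this assay gives 27%. Compound 2 `Nc1n[nH]c2cc(-c3ccccn3)[nH]c(=O)c12` carries a pyridin-2-yl in that position and in this assay gives 47%. Compound 3 `Nc1n[nH]c2cc(-c3cccs3)[nH]c(=O)c12` carries a thiophen-2-yl and in this assay gives 59%, the highest of the three numbers; the nearest, compound 2, lies beyond the scatter below it, and compound 1 lies furthest below.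

Compound 4 `CC(C)(C)c1cc2[nH]nc(N)c2c(=O)[nH]1` is not yet measured. Its structure differs from compound 3 in one place: tert-butyl in place of thiophen-2-yl on an aromatic carbon. Going by the values given here, of the measured steps only the one from compound 1 to compound 3 bears on this, and it is large, a number 32 percentage points higher from compound 1 to compound 3 (beyond the scatter), for thiophen-2-yl in place of methyl. Among the compounds with values here, compound 4 undoes the ring and puts an alkyl back, though a larger one than methyl; no step between two alkyl groups on this carbon has been measured, so the size of any alkyl effect is unknown. The step from compound 3 to compound 4 is therefore expected to be a clear drop, estimated at a number 27 percentage points lower from compound 3 to compound 4 (beyond the scatter). For compound 4 in this assay a value of 32% is estimated, with a range of 15% to 50%.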

Compound 4, a percentage reported as inhibition, at one concentration (the size of the read-out at that concentration, not a potency): 21%
Estimate against measurement, compound 4: 11 percentage points above; low and high end bracket the measured number.
By their numbers in this assay, from the lowest: compounds 4 and 1 (each within the scatter of the next); then compound 2; then compound 3.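

Working notes on the carbon next to the ring nitrogen: in this assay, the step of a number 38 percentage points lower from compound 3 to compound 4 (beyond the scatter) shows that a group of similar heavy-atom count does not by itself retain the higher number seen with thiophen-2-yl, since tert-butyl, with no ring, sits far lower on this read-out. The step of a number 6 percentage points lower from compound 1 to compound 4 (within the scatter) shows that methyl and tert-butyl cannot be told apart here, so across these two alkyl groups the number does not respond to the change in group, and the large difference at this position now separates the thiophen-2-yl of compound 3 from both alkyl groups rather than from methyl alone. Nothing at hand bears on why the aromatic ring and the alkyl groups differ in this way.

Open, on these data alone, is whether an aromatic ring is what matters or any ring would serve, a question that phenyl set against cyclohexyl on this carbon would address. Also open, as far as these compounds go, is how a group such as an amine, a carboxylic acid or a longer alkyl chain would read at this position, and how these single-concentration numbers would translate into potency.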